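Meta-methoxy on the thioether aryl ring of an imidazoline series

The source may report more compounds than this note shows. Statements on the series, on what has been measured and on what is new or still open speak of the compounds shown alone.

Compound 1: `Clc1ccc(Sc2ccc(NC3=NCCN3)cc2)cc1`, 79.4 nM
Compound 2: `c1ccc(Sc2ccc(NC3=NCCN3)cc2)cc1`, 794 nM

Both compounds were tested in an assay (Rattus norvegicus) for binding affinity to prostacyclin receptor (Homo sapiens), read by radioligand binding; on this read-out higher numbers stand for weaker inhibition and lower numbers for stronger inhibition. Compound 2 gives the highest inhibition constant of the two; its nearest neighbour is compound 1, and the step of a 10-fold higher number from compound 1 to compound 2 (1.00 log units; beyond the scatter) shows that removing the chloro from the ring attached through sulfur costs a good deal of affinity.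

Compound 3, `COc1cccc(Sc2ccc(NC3=NCCN3)cc2)c1`, is not yet measured. Relative to compound 2 its change is methoxy in place of hydrogen on an aromatic carbon. For the measured compounds named here, no measured step concerns a methoxy group or this position of the ring; the only step available, from compound 1 to compound 2, concerns a chloro at a different place and was modest but beyond the scatter. It shows that the bare ring of compound 2 is the weaker partner, so a substituent returning to that ring may recover some affinity, but how much a methoxy at this position contributes cannot be read from the present data. The estimate for compound 3 is therefore a cautious expected step of a 1.6-fold lower number from compound 2 to compound 3 (0.20 log units; within the scatter), with wide uncertainty. Compound 3 is expected to give about 500 nM, between 130 nM and 2000 nM.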

Compound 3, inhibition constant: 398 nM
Estimate against measurement, compound 3: 1.3-fold (0.10 log units) above; the measured number falls inside the stated range.
By their numbers in this assay, from the lowest: compound 1; then compounds 3 and 2 (each within the scatter of the next).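

In this assay a methoxy in place of hydrogen on the ring attached through sulfur, meta to a large group, gives a 2.0-fold lower number from compound 2 to compound 3 (0.30 log units; within the scatter) and so stays within the scatter, which means that this read-out does not separate the methoxy compound from its unsubstituted parent. For the compounds shown here, the only earlier step, a 10-fold higher number from compound 1 to compound 2 (1.00 log units; beyond the scatter) on removal of a chloro, lay beyond the scatter, so the series now holds one change on this ring that clearly registers and one that does not, but those two steps differ in both the group and its place, and neither factor can be isolated from them. Nothing measured on these compounds accounts for the small size of the methoxy step.

The compounds shown leave open whether a methoxy at the place held by the chloro in compound 1, or a chloro at the place held by the methoxy in compound 3, would register in this read-out. They also leave open whether an amine, a carboxylic acid or a longer alkoxy chain at this position would move the number beyond the scatter.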